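Chloro in place of hydrogen on compound 1

A few compounds are considered here, and "the series" means these few. Any claim that something is new, unique, unknown or untested is made for them only; others in the source may bear on it.

Measured in an ADME assay for permeability, using PAMPA, at pH 4; a lower number here means that the compound crosses the layer more slowly, a higher number that the compound crosses the layer faster:
- compound 1 `Cc1[nH]c2ccccc2c(=O)c1Cc1ccccc1`: 110 10^-6 cm/s
- compound 2 `COc1ccc2[nH]c(C)c(Cc3ccccc3)c(=O)c2c1`: 167 10^-6 cm/s

The two measured compounds lie within the scatter of each other, so compound 1 has no distinct standing on these numbers. Compound 3 `Cc1[nH]c2c(Cl)cccc2c(=O)c1Cc1ccccc1` is not yet measured and differs from compound 1 by chloro in place of hydrogen on an aromatic carbon. Within the data shown here, the only measured step that bears on it is a 1.5-fold higher number from compound 1 to compound 2 (0.18 log units; within the scatter), a methoxy replacement, and this is a single and only loose guide. No step beyond the scatter is therefore expected in this assay. The estimated change is a 1.3-fold higher number from compound 1 to compound 3 (0.10 log units; within the scatter). For compound 3 the expected value is 140 10^-6 cm/s, with an estimated range of 70 10^-6 cm/s to 280 10^-6 cm/s.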

Compound 3, apparent permeability: 430 10^-6 cm/s
Compound 3: the middle estimate sits 3.1-fold (0.49 log units) below what was measured; the whole stated range lies below it.
By their numbers in this assay, from the lowest: compounds 1 and 2 (each within the scatter of the next); then compound 3.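

In this assay, among these compounds, chloro in place of hydrogen on an aromatic carbon, ortho to a fused ring and meta to a fused ring, gives a 3.9-fold higher number from compound 1 to compound 3 (0.59 log units; beyond the scatter) and is the first step beyond the scatter. The methoxy replacement, with a 1.5-fold higher number from compound 1 to compound 2 (0.18 log units; within the scatter), stayed within it, so the core of compound 1 can respond to a single replacement of one hydrogen. Nothing at hand accounts for the size of this step.

The compounds shown leave open whether the step belongs to chloro or to this place. Fluoro, bromo or an amine on the same carbon, and chloro on another aromatic carbon, could separate the two.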